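Swapping Carbamoyl for Tetrazole: Expected Solubility of Compound 4

The source may report more compounds than this note shows. Statements on the series, on what has been measured and on what is new or still open speak of the compounds shown alone.

Compound 1 `NC(=O)c1ccc(-c2cnc3ccc(-c4cccc(S(=O)(=O)C5CC5)c4)nn23)cc1` has been measured in a physicochemical assay for solubility, at pH 6.5 (on this read-out lower numbers stand for lower solubility and higher numbers for higher solubility), and gives only a limit there, < 5000 nM, not a number. Compound 2 `C[S+]([O-])c1cccc(-c2ccc3ncc(-c4ccc(C(N)=O)cc4)n3n2)c1`, in which a group of 3 heavy atoms stands in place of the cyclopropylsulfonyl group, likewise gives only a limit, < 5000 nM. Compound 3 `CS(=O)(=O)c1ccc(-c2cnc3ccc(-c4cccc(S(=O)(=O)C5CC5)c4)nn23)cn1`, with 6-(methylsulfonyl)pyridin-3-yl in place of 4-carbamoylphenyl, also gives only a limit, < 5000 nM. Because all three values sit at the limit of < 5000 nM in this assay, at which 3 of the 3 values shown sit, the step that the two limits leave unreadable from compound 1 to compound 2 and the step that the two limits leave unreadable from compound 1 to compound 3 cannot be read in size or direction. Compound 4 `O=S(=O)(c1cccc(-c2ccc3ncc(-c4ccc(-c5nnn[nH]5)cc4)n3n2)c1)C1CC1` is not yet measured and differs from compound 1 in one place: 1H-tetrazol-5-yl in place of carbamoyl on an aromatic carbon. Among the measured compounds shown here, neither measured step alters the carbamoyl group, so no measured step bears directly on this change. The step from compound 1 to compound 4 is therefore expected to be an at least 1.4-fold higher number from compound 1 to compound 4 (0.14 log units; that floor lies within the scatter), resting on the change of group alone. Compound 4 is expected to give 7000 nM in this assay. That estimate for compound 4 spans from 1500 nM to 30000 nM, with a real chance that only a limit is reported again.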

Compound 4, solubility: 183000 nM
For compound 4 the middle estimate is 26-fold (1.42 log units) below the measured one; the whole stated range lies below it.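

At this position, on an aromatic carbon para to a large group, 1H-tetrazol-5-yl in place of carbamoyl gives an at least 36-fold higher number from compound 1 to compound 4 (1.56 log units; beyond the scatter) in this assay. Among the compounds shown here, the two earlier steps cannot be read, so this is the first change in the set with both a direction and a lower bound on its size. Compound 4 is also the only compound shown that gives a number rather than a limit, and so it stands apart from the rest: the limit of < 5000 nM in this assay, at which 3 of the 4 values shown sit.

The full size of the step stays open, as compound 1 gives only a limit, and nothing shown says why this swap has such an effect. Also open, from the compounds shown here alone, is whether another group in the same place, such as a carboxylic acid or an amine, would give a step like this one, and whether the tetrazole would do the same on compound 2.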